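Swapping the oxazole for an unsubstituted pyrazole

The compounds below may be only part of what the source reports. "The series", "measured", "known", "first", "only" and "open" are said of these compounds alone.

Compound 1 `Cc1c(Cc2ccc(C(F)(F)F)nc2)c[nH]c1C(=O)NC(C)c1cnn(C)c1` gives 95.1%
Compound 2 `Cc1cc(C(C)NC(=O)c2[nH]cc(Cc3ccc(C(F)(F)F)nc3)c2C)no1` gives 93.7%

For the measured compounds named here, in an ADME assay on a cell-free system (plasma, Rattus norvegicus) for protein binding, compound 2 stands within the scatter of compound 1, the only other compound measured. Exchanging 1-methyl-1H-pyrazol-4-yl for 5-methyl-1,2-oxazol-3-yl gave a small step (a 1.3-fold higher unbound fraction from compound 1 to compound 2 (0.11 log units; within the scatter)). The next compound, compound 3 `Cc1c(Cc2ccc(C(F)(F)F)nc2)c[nH]c1C(=O)NC(C)c1cn[nH]c1`, carries 1H-pyrazol-4-yl in place of 5-methyl-1,2-oxazol-3-yl on a saturated chain carbon bound to an amide-type nitrogen and a saturated chain carbon. Going by the values given here, that single measured step is the only guide at this place, and no compound with the entering group has been measured. A similarly small change is therefore expected in this assay, tentatively towards more unbound compound and probably not beyond the scatter (a 1.4-fold higher unbound fraction from compound 2 to compound 3 (0.15 log units; within the scatter)). Compound 3 is estimated at 91% (expected range 84% to 95.5%).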

Compound 3, plasma protein binding in the Rattus norvegicus assay: 91.4%
For compound 3 the middle estimate is 1.0-fold (0.02 log units) (unbound fraction) above the measured one, and the stated range covers the measured number.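

In the Rattus norvegicus assay, neither the exchange of 5-methyl-1,2-oxazol-3-yl for 1H-pyrazol-4-yl (a 1.4-fold higher unbound fraction from compound 2 to compound 3 (0.14 log units; within the scatter)) nor hydrogen in place of methyl on an aromatic nitrogen (a 1.8-fold higher unbound fraction from compound 1 to compound 3 (0.24 log units; within the scatter)) moves the result outside the scatter. All three ring variants on this saturated chain carbon therefore remain indistinguishable in that assay. In a physicochemical assay for solubility, in simulated intestinal fluid, with a stated time of 5 h, at pH 6.5 (on this read-out higher numbers stand for higher solubility and lower numbers for lower solubility), compound 2 gives 9.9 ug/mL and compound 3 gives 34 ug/mL. In the physicochemical assay, the first of these exchanges does produce a difference beyond the scatter: the measured solubility of compound 2, 9.9 ug/mL, and of compound 3, 34 ug/mL, a 3.4-fold higher number (0.54 log units; beyond the scatter)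

The compounds shown do not separate the hydrogen-bond donor of 1H-pyrazol-4-yl from its other differences to 5-methyl-1,2-oxazol-3-yl. Going by these compounds, whether a carboxylic acid or an amine at this place would take the Rattus norvegicus assay beyond the scatter also remains open.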